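Chloro on the benzamide ring of the imidazole amides

A few compounds are considered here, and "the series" means these few. Any claim that something is new, unique, unknown or untested is made for them only; others in the source may bear on it.

Compound 1 `Cn1c(-c2ccccc2)cnc1NC(=O)c1ccc(F)cc1` pairs an unsubstituted phenyl on the shared core with a fluorinated benzamide. In a toxicity assay on THP-1 cells (Homo sapiens) for inhibition (on this read-out lower numbers stand for higher toxicity in this test and higher numbers for lower toxicity in this test), compound 1 gives only a limit, > 100000 nM. Compound 2 `Cn1c(-c2ccccc2Cl)cnc1NC(=O)c1ccc(F)cc1` differs from compound 1 by chloro in place of hydrogen on an aromatic carbon. In this assay compound 2 also gives only a limit, > 50000 nM. The step that the two limits leave unreadable from compound 1 to compound 2 cannot be read because the limit of > 100000 nM in this assay, at which 2 of the 3 values shown sit, and the limit of > 50000 nM in this assay, at which 1 of the 3 values shown sits, are both limits of the test.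

Compound 3 `COc1ccc(-c2cnc(NC(=O)c3ccccc3)n2C)cc1` carries a different core; how its core differs from that of compound 1 is not broken down here. In this assay compound 3 gives only a limit, > 100000 nM. Of the three values shown, none is a number; every one is a limit.

Compound 4 `COc1ccc(-c2cnc(NC(=O)c3cccc(Cl)c3)n2C)cc1` has not been measured in this assay. It differs from compound 3 by chloro in place of hydrogen on an aromatic carbon. This is the same kind of change as that from compound 1 to compound 2, but the place is not the same: in compound 2 the chloro sits ortho to a large group, in compound 4 it sits meta to a large group.

The step from compound 1 to compound 2 left no readable size, and compound 3 sits at a limit. The expected step of a number no higher from compound 3 to compound 4 (the limit leaves the size open) is accordingly small. For compound 4 the expected value in this assay is 100000 nM, estimated between 30000 nM and 300000 nM, most likely again reported as a limit.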

Compound 4, half-maximal cytotoxic concentration: > 28000 nM
Compound 4: only a limit was reported (the forecaster's own chance of this, stated with the estimate: 80%); the middle value does not contradict the limit.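

Compound 4 gives only a limit in this assay (> 28000 nM). Among the compounds shown here, compound 3 also stands at a limit, so the step between compound 3 and compound 4 cannot be read, and no new step follows from this result. With all four values being limits, the compounds shown leave open whether chloro in place of hydrogen on an aromatic carbon changes the read-out in this assay at all.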